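Swapping an aromatic group on a shared core

The compounds below may be only part of what the source reports. "The series", "measured", "known", "first", "only" and "open" are said of these compounds alone.

Measured in a functional assay on SMMC-7721 cells (Homo sapiens) for cytotoxicity, read by MTT assay, with a stated time of 72 h; on this read-out higher numbers stand for weaker inhibition and lower numbers for stronger inhibition:
- compound 1 `O=C1C(=Cc2ccc(O)cc2)C(=O)N(c2ccc(Cl)cc2)N1c1ccc(Cl)cc1`: 20600 nM
- compound 2 `COc1cccc(C=C2C(=O)N(c3ccc(Cl)cc3)N(c3ccc(Cl)cc3)C2=O)c1OC`: 14100 nM

Within the data shown here, only these two compounds have numbers so far. Compound 2 gives 14100 nM and compound 1 gives 20600 nM, so the two cannot be told apart by this measurement. Compound 3 `O=C1C(=Cc2ccc(F)cc2F)C(=O)N(c2ccc(Cl)cc2)N1c1ccc(Cl)cc1` keeps the same core and has not yet been measured. It differs from compound 2 in a single group: 2,4-difluorophenyl in place of 2,3-dimethoxyphenyl on a double-bonded chain carbon bound to a double-bonded ring carbon.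

Among the measured compounds shown here, one measured step bears on this change, because a 1.5-fold lower number from compound 1 to compound 2 (0.16 log units; within the scatter) exchanged one substituted phenyl group for another at the same place and stayed within the scatter. That is a single step, so it shows no general pattern. For the measured compounds named here, no measured compound carries a 2,4-difluorophenyl group, which leaves the estimate uncertain. No step beyond the scatter is therefore expected in this assay, and the estimated step is a 1.1-fold higher number from compound 2 to compound 3 (0.03 log units; within the scatter). For compound 3 the expected value is 15000 nM, with an estimated range of 6000 nM to 40000 nM.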

Compound 3, half-maximal inhibitory concentration: 35800 nM
Estimate against measurement, compound 3: 2.4-fold (0.38 log units) below; low and high end bracket the measured number.
By their numbers in this assay, from the lowest: compounds 2, 1 and 3 (each within the scatter of the next, the first and the last beyond it).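

In this assay, this position shows its first change beyond the scatter, with a 2.5-fold higher number from compound 2 to compound 3 (0.40 log units; beyond the scatter) when 2,4-difluorophenyl replaces 2,3-dimethoxyphenyl on a double-bonded chain carbon bound to a double-bonded ring carbon. The aromatic group here is therefore not freely interchangeable, but the step is modest and rests on one pair, and the other new comparison, a 1.7-fold higher number from compound 1 to compound 3 (0.24 log units; within the scatter), stays within the scatter, leaving the 4-hydroxyphenyl group of compound 1 indistinguishable from the 2,4-difluorophenyl group. No supporting measurement is available to explain the difference between compound 2 and compound 3.

The step from compound 2 to compound 3 removes both methoxy groups and introduces both fluorine atoms at once, so the compounds shown cannot separate the contribution of either change; a phenyl ring carrying a single methoxy group or a single fluorine atom would begin to address this. It also remains open how this position would respond to a group outside the substituted phenyl family shown here, such as a pyridine ring, or to a phenyl ring bearing an amine or a carboxylic acid.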